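Trifluoromethoxy to methyl on the aryl ring

This account rests on a few compounds, and the source may have more. Where it says the series, first, only, none or still open, it means among the compounds named here.

Measured compounds:
Compound 1 `Cc1ccc2c(c1)C(=O)/C(=C(\S)N(C)c1ccccc1)C(=O)N2C` gives 20%.
Compound 2 `CN1C(=O)/C(=C(/S)N(C)c2ccc(OC(F)(F)F)cc2)C(=O)c2cc(Cl)ccc21` gives 39%.

Among the compounds with values here, in a functional assay on the whole organism for inhibition, with Mus musculus as the target, at a dose of 10 mg/kg by the oral route (a higher number here means more inhibition at the dose given (going by the name of the read-out), a lower number less inhibition), compound 2 stands highest of the two numbers known; compound 1, the nearest, gives a lower number, a gap beyond the usual scatter. Compound 3 `Cc1ccc(N(C)/C(S)=C2/C(=O)c3cc(Cl)ccc3N(C)C2=O)cc1` differs from compound 2 in one place: methyl in place of trifluoromethoxy on an aromatic carbon. Within the data shown here, no measured pair shows this exact step, so its size can only be estimated. A modest drop is expected, with the step from a number 11 percentage points lower from compound 2 to compound 3 (beyond the scatter) estimated as a decrease, though not beyond the scatter with certainty. Compound 3 is therefore expected to give 28%, in the range 10% to 45%.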

Compound 3, a percentage reported as inhibition, in the whole organism at one dose (the size of the read-out at that dose, not a potency): 23%
Beside the measured number, compound 3's estimate is 5 percentage points above it; measured number inside the range.
By their numbers in this assay, from the lowest: compounds 1 and 3 (each within the scatter of the next); then compound 2.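

In this assay, within the data shown here, the single change on an aromatic carbon para to a large group, methyl in place of trifluoromethoxy, gives a number 16 percentage points lower from compound 2 to compound 3 (beyond the scatter) with the rest of the molecule held fixed. Among these compounds, this is the first comparison in one place, and it shows that the group at this position matters to the read-out. Nothing measured gives a reason for the step. As far as these compounds go, it remains open how methoxy, chlorine or an amine would compare at this position, and whether the step would hold on the core of compound 1.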